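The source may hold more compounds than are shown below. What is called first, only, known or untested is meant among the compounds shown, and "the series" means these compounds.

Compound 1 `C[C@H](N)[C@H]1COC(c2ccccc2)(c2ccccc2)O1` gives 607 nM in a functional assay (brain) for displacement of a labelled ligand, with Rattus norvegicus as the target; on this read-out lower numbers stand for stronger inhibition and higher numbers for weaker inhibition.
Compound 2 `CN[C@@H](C)[C@H]1COC(c2ccccc2)(c2ccccc2)O1` gives 703 nM in this assay.
Compound 3 `CCNC[C@H]1COC(c2ccccc2)(c2ccccc2)O1` gives 8400 nM in this assay.

Among these three, compound 3 carries the highest number: its nearest neighbour is compound 2 and its furthest is compound 1, and both gaps lie beyond the scatter (a 12-fold higher number from compound 2 to compound 3 (1.08 log units; beyond the scatter); a 14-fold higher number from compound 1 to compound 3 (1.14 log units; beyond the scatter)). Compound 4 `CCN[C@@H](C)[C@H]1COC(c2ccccc2)(c2ccccc2)O1` has not yet been measured in this assay. It differs from compound 3 by methyl in place of hydrogen on a saturated chain carbon bound to an amine nitrogen and a saturated ring carbon; cut one bond further out, the change reads (ethylamino)methyl to 1-(ethylamino)ethyl. For the measured compounds named here, two measured steps bear on this. The step of a 14-fold higher number from compound 1 to compound 3 (1.14 log units; beyond the scatter) and the step of a 12-fold higher number from compound 2 to compound 3 (1.08 log units; beyond the scatter) each take away a methyl from the saturated chain carbon bound to an amine nitrogen and a saturated ring carbon while also altering the group on the amine nitrogen, and both raise the number by a large amount. The step of a 1.2-fold higher number from compound 1 to compound 2 (0.06 log units; within the scatter), which changes only the group on the amine nitrogen, lies within the scatter. The step from compound 3 to compound 4 restores the methyl on that chain carbon while keeping the ethyl on the nitrogen, so a large fall in the number is expected. Compound 4 is expected to give about 800 nM, within 300 nM to 2500 nM, an expected step of an 11-fold lower number from compound 3 to compound 4 (1.02 log units; beyond the scatter).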

Compound 4, inhibition constant: 9000 nM
Estimate against measurement, compound 4: 11-fold (1.05 log units) below, and the stated range ends below it.
By their numbers in this assay, from the lowest: compounds 1 and 2 (each within the scatter of the next); then compounds 3 and 4 (each within the scatter of the next).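

In this assay, adding the methyl on the saturated chain carbon bound to an amine nitrogen and a saturated ring carbon, with ethyl kept on the nitrogen, gives a 1.1-fold higher number from compound 3 to compound 4 (0.03 log units; within the scatter), so this methyl alone does not account for the large steps to compound 3, which changed that carbon and the nitrogen group together. With the chain methyl kept, changing only the nitrogen group gives large steps: a 15-fold higher number from compound 1 to compound 4 (1.17 log units; beyond the scatter) for ethyl in place of hydrogen, and a 13-fold higher number from compound 2 to compound 4 (1.11 log units; beyond the scatter) for ethyl in place of methyl. Among these four compounds, the two carrying ethyl on the nitrogen therefore stand together at the high end and none goes against this, but nothing available explains the pattern.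

The compounds shown leave open whether the chain methyl matters when the nitrogen carries hydrogen or methyl, as an aminomethyl or a (methylamino)methyl group in place of the 1-aminoethyl or 1-(methylamino)ethyl group would test. They also leave open whether a propyl group or a longer chain on the nitrogen would stand with the ethyl compounds.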